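Changing the Amide Group of Compound 2

The compounds below may be only part of what the source reports. "The series", "measured", "known", "first", "only" and "open" are said of these compounds alone.

In a functional assay on EBC-1 cells (Homo sapiens) for antiproliferative activity, with a stated time of 72 h (a higher number here means a weaker inhibitor, a lower number a stronger inhibitor), compound 1 `N#Cc1ccc(-c2cc(F)c3ncc(Cc4ccc5ncccc5c4)n3c2)cn1` gives 189 nM while compound 2 `O=C(c1ccc(-c2cc(F)c3ncc(Cc4ccc5ncccc5c4)n3c2)cc1F)N1CCC2(COC2)C1` gives 406 nM as the higher of the two numbers, a gap beyond the usual scatter. Compound 3 `O=C(NCCCN1CCCC1)c1ccc(-c2cc(F)c3ncc(Cc4ccc5ncccc5c4)n3c2)cc1F` keeps the shared core and differs from compound 2 on the carbonyl carbon by a group of 9 heavy atoms (7 carbon, 2 nitrogen; one five-membered non-aromatic ring with 1 hetero atom) in place of a group of 8 heavy atoms (6 carbon, 1 nitrogen, 1 oxygen; one four-membered non-aromatic ring with 1 hetero atom, one five-membered non-aromatic ring with 1 hetero atom), on a carbonyl carbon and has not yet been measured. Among the measured compounds shown here, no measured step shows what this swap does, so only a modest move towards a lower number is expected, and the estimated change is a 1.6-fold lower number from compound 2 to compound 3 (0.21 log units; within the scatter) in size. For compound 3 the estimated value is 250 nM with an expected range from 50 nM to 1000 nM given how little is known.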

Compound 3, half-maximal inhibitory concentration: 161 nM
Beside the measured number, compound 3's estimate is 1.6-fold (0.19 log units) above it, within the range that was stated.
By their numbers in this assay, from the lowest: compounds 3 and 1 (each within the scatter of the next); then compound 2.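

In this assay, placing (3-(pyrrolidin-1-yl)propyl)amino on the carbonyl carbon gives a 2.5-fold lower number from compound 2 to compound 3 (0.40 log units; beyond the scatter), the first sign that the number responds to what is attached at this position. The swap changes several things at once: the four-membered ring is lost, while a chain and a hydrogen-bond donor enter, so this single step cannot separate their contributions. Going by these compounds, whether a shorter chain such as (2-(pyrrolidin-1-yl)ethyl)amino, or a piperidine ring in place of the pyrrolidine, would shift the number remains open. No supporting data are available to explain the step.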